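The source may report more compounds than this note shows. Statements on the series, on what has been measured and on what is new or still open speak of the compounds shown alone.

Working notes on the series. For the measured compounds named here, in a functional assay on HT-1080 cells (Homo sapiens) for antiproliferative activity, read by sulforhodamine B assay, with a stated time of 48 h (a higher number here means a weaker inhibitor, a lower number a stronger inhibitor), compound 2 `CC(=O)Nc1ccc(S(=O)(=O)Oc2ccccc2C(C)C)cc1` gives 12000 nM, the highest of the three numbers so far, though compound 1 `CC(C)c1ccccc1OS(=O)(=O)c1cccc(NC(=O)CCCl)c1` gives 8200 nM, a figure within the usual scatter of it; compound 3 `CCCNC(=O)Nc1ccc(S(=O)(=O)Oc2ccccc2I)cc1` gives 700 nM, well beyond the scatter below both. Compound 4 `CC(C)c1ccccc1OS(=O)(=O)c1ccc(NC(=O)NCCCCl)cc1` is not yet measured. It differs from compound 2 by (3-chloropropyl)amino in place of methyl on a carbonyl carbon; read one bond further out, acetamido becomes ((3-chloropropyl)carbamoyl)amino. Going by the values given here, no measured pair isolates this change, so the step is expected only from what the three values show. Compound 3 gives 700 nM, while compound 2 gives 12000 nM. A step toward lower numbers, beyond the scatter, is expected: a 4.8-fold lower number from compound 2 to compound 4 (0.68 log units; beyond the scatter). Compound 4 is estimated at 2500 nM, within a range from 800 nM to 8000 nM.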

Compound 4, half-maximal inhibitory concentration: 2700 nM
Compound 4: the middle estimate sits 1.1-fold (0.03 log units) below what was measured; measured number inside the range.
By their numbers in this assay, from the lowest: compound 3; then compound 4; then compounds 1 and 2 (each within the scatter of the next).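

In this assay, (3-chloropropyl)amino in place of methyl on a carbonyl carbon gives a 4.4-fold lower number from compound 2 to compound 4 (0.65 log units; beyond the scatter). For the compounds shown here, this is the first single-place comparison, and it shows that this carbonyl carbon accepts the larger group, with its added hydrogen-bond donor, and that the number falls. Nothing available explains the step.

From the compounds shown here alone, how much of the step belongs to the chlorine and how much to the added nitrogen stays open. (3-Hydroxypropyl)amino or the longer (4-chlorobutyl)amino at this carbonyl carbon would bear on that.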